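The source may hold more compounds than are shown below. What is called first, only, known or untested is meant among the compounds shown, and "the series" means these compounds.

Values in a functional assay on the whole organism (strain Swiss) with Mus musculus as the target, in the maximal electroshock model, with a stated time of 0.25 h, at a dose of 100 mg/kg by the intraperitoneal route; a higher number here means a stronger effect of the compound at the dose given, a lower number a weaker effect:
compound 1 , `CCC(C(=O)N1CCN(c2cccc(Cl)c2)CC1)N1C(=O)CCC1=O`: 50%
compound 2 , `COCC(C(=O)N1CCN(c2cccc(C(F)(F)F)c2)CC1)N1C(=O)CCC1=O`: 100%
compound 3 , `CC(C(=O)N1CCN(c2ccc(Cl)cc2)CC1)N1C(=O)CCC1=O`: 50%

Compound 1 stands level with compound 3 at the digits given, within the scatter, and the two share the lowest value of the three in this assay. Compound 2 lies higher than compound 1 by a gap well beyond the scatter.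

Compound 4 , `CCC(C(=O)N1CCN(c2cccc(F)c2)CC1)N1C(=O)CCC1=O`, is not yet measured. It differs from compound 1 in one place: fluoro in place of chloro on an aromatic carbon. For the measured compounds named here, no measured pair in this set carries that change, so its effect has no direct precedent here. The step of a number 10 percentage points lower from compound 1 to compound 4 (within the scatter) is expected to be small, downward or none beyond the scatter. Compound 4 is accordingly estimated at 40%, with a range from 10% to 75%.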

Compound 4, a percentage reported as activity, at one dose (the size of the read-out at that dose, not a potency): 0%
For compound 4 the middle estimate is 40 percentage points above the measured one; the whole stated range lies above it.
By their numbers in this assay, from the lowest: compound 4; then compounds 1 and 3 (each within the scatter of the next); then compound 2.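

In this assay, for the compounds shown here, 3-chlorophenyl to 3-fluorophenyl gives the first comparison that differs in one place, and it comes with a number 50 percentage points lower from compound 1 to compound 4 (beyond the scatter). On this aromatic carbon, meta to a large group, exchanging one halogen for another is therefore enough to change the read-out at this dose. Nothing available explains this step.

Bromo or methyl on the same carbon would show whether the read-out follows a wider trend or whether fluoro alone stands apart. From the compounds shown here alone, whether the same exchange has a similar effect with other side chains on the shared core also remains open.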